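From pyridin-4-yl to pyrimidin-5-yl on the amine nitrogen

The source may report more compounds than this note shows. Statements on the series, on what has been measured and on what is new or still open speak of the compounds shown alone.

In a functional assay on VCaP cells (Homo sapiens) for antiproliferative activity, read by CCK-8 assay, with a stated time of 6 days (a higher number here means a weaker inhibitor, a lower number a stronger inhibitor), compound 1 `C[C@@H](Cn1ccc(-c2ccc(C#N)c(Cl)c2)n1)Nc1ccccc1` reaches only a limit of the assay, > 30000 nM. Within the data shown here, compound 2 `C[C@@H](Cn1ccc(-c2ccc(C#N)c(Cl)c2)n1)Nc1ccncc1` gives 9900 nM, the only actual number so far. Compound 3 `C[C@@H](Cn1ccc(-c2ccc(C#N)c(Cl)c2)n1)Nc1cncnc1` differs from it on the amine nitrogen: pyrimidin-5-yl in place of pyridin-4-yl on an amine nitrogen. Among the measured compounds shown here, the sole measured step bearing on this is an at least 3.0-fold lower number from compound 1 to compound 2 (0.48 log units; beyond the scatter), which brought in pyridin-4-yl in place of phenyl, and no measured step covers pyrimidin-5-yl. The estimate is therefore a modest move toward weaker inhibition, a 1.4-fold higher number from compound 2 to compound 3 (0.15 log units; within the scatter). Compound 3 is expected near 14000 nM, within an estimated range of 5000 nM to 30000 nM.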

Compound 3, half-maximal inhibitory concentration: > 30000 nM
Compound 3: only a limit was reported; the forecaster's own chance of this, stated with the estimate: 35%; middle value at least 2.1-fold (0.33 log units) away from the limit.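

On the amine nitrogen, pyrimidin-5-yl does not hold what pyridin-4-yl gave: in this assay the change produces an at least 3.0-fold higher number from compound 2 to compound 3 (0.48 log units; beyond the scatter). A second hetero atom in the ring therefore does not carry the number of compound 2 over, and of the three aromatic rings only pyridin-4-yl gives an actual value. The step from phenyl to pyrimidin-5-yl cannot be read, and the series sits largely at the assay's limit: the limit of > 30000 nM in this assay, at which 2 of the 3 values shown sit.

As far as these compounds go, whether a pyrazine ring or an acetyl group on the amine nitrogen would give a measurable number stays open. So does how compound 1 and compound 3 rank against each other.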